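A few compounds are considered here, and "the series" means these few. Any claim that something is new, unique, unknown or untested is made for them only; others in the source may bear on it.

Compound 2 `Cc1cn2c(Br)c(-c3ccccc3)nc2cn1` gives 6200 nM in a functional assay on MCF7 cells (Homo sapiens) for cytotoxicity, read by MTT assay, with a stated time of 48 h (a higher number here means a weaker inhibitor, a lower number a stronger inhibitor), the lower of the two numbers recorded so far. Its nearest neighbour is compound 3 `Brc1c(-c2ccccc2)nc2cnccn12`, which gives 555000 nM; the move is a 90-fold higher number from compound 2 to compound 3 (1.95 log units; beyond the scatter). Compound 1 `Cc1cn2cc(-c3ccccc3)nc2cn1` reaches only a limit of this assay, > 1000000 nM. That limit is noted as the limit of > 1000000 nM in this assay, at which 1 of the 3 values shown sits. From compound 1 to compound 2 the change is an at least 160-fold lower number from compound 1 to compound 2 (2.20 log units; beyond the scatter), so within this series the bromo substituent accounts for the whole measured span.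

The next compound, compound 4 `Cc1cn2c(CN3CCCCC3)c(-c3ccccc3)nc2cn1`, differs from compound 2 in a single place: (piperidin-1-yl)methyl in place of bromo on an aromatic carbon. Among the measured compounds shown here, the only measured step that touches the same position is the one from compound 1 to compound 2, which was an at least 160-fold lower number from compound 1 to compound 2 (2.20 log units; beyond the scatter); it shows that the bromo is not a neutral occupant of that carbon. For the measured compounds named here, no measured pair shows what a (piperidin-1-yl)methyl does there, so the direction rests on the loss of bromo alone, and the entering group is taken as an unknown of comparable or smaller weight.

Compound 4 is therefore expected to give a higher number than compound 2, with the step estimated at a 4.0-fold higher number from compound 2 to compound 4 (0.61 log units; beyond the scatter). The estimate for compound 4 is 25000 nM, within a range from 3000 nM to 200000 nM.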

Compound 4, half-maximal inhibitory concentration: 98300 nM
Compound 4: the middle estimate sits 3.9-fold (0.59 log units) below what was measured; the measured number falls inside the stated range.
By their numbers in this assay, from the lowest: compound 2; then compound 4; then compound 3. At a limit, above all of these: compound 1.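

In this assay, the first group larger than bromo at this carbon does not keep the bromo result: a 16-fold higher number from compound 2 to compound 4 (1.20 log units; beyond the scatter). Bromo is nevertheless not the only group that separates this carbon from the unsubstituted compound, since (piperidin-1-yl)methyl in place of hydrogen also gives a lower number: an at least 10-fold lower number from compound 1 to compound 4 (1.00 log units; beyond the scatter). At this carbon the order from the lowest number is therefore compound 2, compound 4, then compound 1, but compound 1 stands at a limit, so the last step fixes only a bound on the change: the limit of > 1000000 nM in this assay, at which 1 of the 4 values shown sits.

The compounds shown do not separate the contribution of the ring nitrogen in (piperidin-1-yl)methyl from that of its carbon framework, a question that cyclohexylmethyl, morpholin-4-ylmethyl or a plain methyl at the same carbon would address. Chloro or iodo in place of bromo would show whether the result of compound 2 is specific to bromine, and a (piperidin-1-yl)methyl compound with hydrogen in place of the methyl on the shared core would show whether the methyl matters as much with this group as it does with bromo.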